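A few compounds are considered here, and "the series" means these few. Any claim that something is new, unique, unknown or untested is made for them only; others in the source may bear on it.

Measured so far:
Compound 2 `CC(=O)c1ccc(OCCCCOc2ccc(C(=O)O)cc2C)c(C)c1O`: 50 nM in an assay on HEK293 cells for positive allosteric modulation of metabotropic glutamate receptor 2 (Rattus norvegicus), read by thallium flux, with a stated time of 2.5 min; on this read-out lower numbers stand for an effect already at smaller amounts and higher numbers for an effect only at larger amounts of compound
Compound 1 `COc1cc(C(=O)O)ccc1OCCCCOc1ccc(C(=O)C(C)C)c(O)c1C`: 113 nM in this assay

Of the two numbers in this assay, compound 2 holds the lower one, and the number for compound 1 lies above it by more than the usual scatter of such measurements. Compound 3 `COc1cc(C(=O)O)ccc1OCCCCOc1ccc(C(C)=O)c(O)c1C` is the next compound to be measured. It is built from compound 2 by a single change: methoxy in place of methyl on an aromatic carbon. Within the data shown here, no pair of measured compounds differs in only this way, so the size of the step it brings can only be guessed. A small shift toward a higher number in this assay seems the most likely outcome, though one that may not clear the scatter. The expected step of a 1.6-fold higher number from compound 2 to compound 3 (0.20 log units; within the scatter) reflects this. Compound 3 is therefore estimated at 80 nM in this assay, with a plausible range from 35 nM to 200 nM.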

Compound 3, half-maximal effective concentration: 161 nM
The estimate for compound 3 lay 2.0-fold (0.30 log units) below the measured number, within the range that was stated.
By their numbers in this assay, from the lowest: compound 2; then compounds 1 and 3 (each within the scatter of the next).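

On the aromatic carbon ortho to a large group and meta to a carboxy group, methoxy in place of methyl gives a clear change in this assay (a 3.2-fold higher number from compound 2 to compound 3 (0.51 log units; beyond the scatter)), so what this position carries is not a matter of indifference. On a carbonyl carbon, methyl in place of isopropyl gives a 1.4-fold higher number from compound 1 to compound 3 (0.15 log units; within the scatter), a difference that cannot be told apart from repeat-to-repeat variation. Nothing available here accounts for the methoxy step.

Still open, on these data alone, is how a hydrogen, a chlorine atom or an ethyl group on that aromatic carbon would compare with methyl and methoxy. Also open, as far as these compounds go, is whether an ethyl or a cyclopropyl group on the carbonyl carbon would likewise leave the number within the scatter.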